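The source may hold more compounds than are shown below. What is called first, only, known or untested is meant among the compounds shown, and "the series" means these compounds.

Of the compounds shown here, two have been measured so far in a functional assay on HL-60 cells (Homo sapiens) for inhibition, read by MTT assay, with a stated time of 72 h (on this read-out lower numbers stand for stronger inhibition and higher numbers for weaker inhibition), and they lie apart by more than the usual scatter. Compound 1 `Cc1ccc(C)c(N2CCN(C(=O)c3oc(C)nc3-c3ccc(F)cc3)CC2)c1` gives 358 nM while compound 2 `Cc1nc(-c2ccccc2F)c(C(=O)N2CCN(c3cc(Cl)cc(Cl)c3)CC2)o1` gives 60.2 nM as the lower of the two numbers. Compound 3 `Cc1nc(-c2ccc(F)cc2)c(C(=O)N2CCN(c3cc(Cl)cc(Cl)c3)CC2)o1` is still unmeasured. The change 4-fluorophenyl in place of 2-fluorophenyl on an aromatic carbon puts 4-fluorophenyl in place of 2-fluorophenyl on an aromatic carbon. Among the measured compounds shown here, no measured pair shows this change alone. Compound 1 also carries 4-fluorophenyl and gives 358 nM but differs from compound 2 elsewhere too, so it offers only weak guidance. A step within the scatter is therefore expected, leaning slightly towards a higher number. The expected result is a 1.2-fold higher number from compound 2 to compound 3 (0.10 log units; within the scatter) as an estimated step. For compound 3 the estimated value is 75 nM with an expected range from 28 nM to 200 nM for the measurement.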

Compound 3, half-maximal inhibitory concentration: 52.1 nM
Compound 3: middle estimate off by 1.4-fold (0.16 log units), on the high side; the range from low to high includes it.
By their numbers in this assay, from the lowest: compounds 3 and 2 (each within the scatter of the next); then compound 1.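

In this assay, 4-fluorophenyl in place of 2-fluorophenyl on the aromatic carbon next to the ring nitrogen gives a step within the scatter (a 1.2-fold lower number from compound 2 to compound 3 (0.06 log units; within the scatter)), so the two placements of fluorine cannot be told apart at this position. Among the compounds shown here, compound 3 also gives the first one-place comparison with compound 1: with 4-fluorophenyl held constant, 3,5-dichlorophenyl in place of 2,5-dimethylphenyl on an amine nitrogen in a ring gives a step beyond the scatter (a 6.9-fold lower number from compound 1 to compound 3 (0.84 log units; beyond the scatter)). No evidence is at hand to explain either step.

The compounds shown leave open whether a 4-methoxyphenyl or 4-aminophenyl group at this position would give a similar number. They also leave open how a single chlorine or an unsubstituted phenyl would read on the amine nitrogen.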